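This account rests on a few compounds, and the source may have more. Where it says the series, first, only, none or still open, it means among the compounds named here.

In a functional assay on COLO 205 cells (Homo sapiens) for inhibition, read by sulforhodamine B assay, with a stated time of 48 h, tested at 50 uM (a higher number here means more inhibition of growth at the concentration tested, a lower number less inhibition of growth), three compounds have been measured so far. Compound 3 `COc1ccccc1/C=C/C(=O)/C=C/c1ccc(OCc2cn(CCCCCOc3cc(=O)oc4ccccc34)nn2)c(OC)c1` gives 30%, compound 1 `COc1ccc(/C=C/C(=O)/C=C/c2ccc(OCc3cn(CCCCOc4cc(=O)oc5ccccc45)nn3)c(OC)c2)cc1OC` gives 53%, and compound 2 `COc1cccc(/C=C/C(=O)/C=C/c2ccc(OCc3cn(CCOc4cc(=O)oc5ccccc45)nn3)c(OC)c2)c1` gives 69%. Compound 2 therefore stands highest of the three, clearly above both others. Compound 4 `COc1ccc(/C=C/C(=O)/C=C/c2ccc(OCc3cn(CCOc4cc(=O)oc5ccccc45)nn3)c(OC)c2)cc1` is the next to be measured, and it differs from compound 2 by one change: 4-methoxyphenyl in place of 3-methoxyphenyl on a double-bonded chain carbon bound to a double-bonded chain carbon. In words, 4-methoxyphenyl takes the place of 3-methoxyphenyl on a double-bonded chain carbon bound to a double-bonded chain carbon. Among the measured compounds shown here, no two measured compounds differ in one place only, so the data offer no direct guide to this change. The expected step, a number 9 percentage points lower from compound 2 to compound 4 (within the scatter), is a small fall that stays within the scatter. Compound 4 is estimated at 60%, with an expected range of 42% to 76%.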

Compound 4, percent growth inhibition at one concentration: 68%
The estimate for compound 4 lay 8 percentage points below the measured number; low and high end bracket the measured number.
By their numbers in this assay, from the lowest: compound 3; then compound 1; then compounds 4 and 2 (each within the scatter of the next).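

In this assay, among the compounds shown here, 4-methoxyphenyl in place of 3-methoxyphenyl on a double-bonded chain carbon bound to a double-bonded chain carbon gives a number 1 percentage points lower from compound 2 to compound 4 (within the scatter), the first comparison that differs in one place only. This read-out therefore does not separate the two methoxyphenyl groups at this position. Nothing available explains this result.

Still open, as far as these compounds go, is how this position responds to a phenyl carrying an amine or a carboxylic acid. From the compounds shown here alone, it is also open whether the same change behaves alike with the longer chains of compound 1 and compound 3.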